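The source may report more compounds than this note shows. Statements on the series, on what has been measured and on what is new or still open speak of the compounds shown alone.

Three compounds share one core and differ only in the group carried on an amine nitrogen in a ring. Compound 1 `Nc1scc(CN2CCN(c3cc(Cl)cc(Cl)c3)CC2)c1C(=O)c1ccc(Cl)cc1` bears a 3,5-dichlorophenyl there, and in a functional assay on CHO cells with adenosine receptor A1 (Homo sapiens) as the target, read by cAMP accumulation and immunoassay, with a stated time of 6 min, tested at 0.1 uM (on this read-out lower numbers stand for a stronger effect and higher numbers for a weaker effect at the one concentration tested), compound 1 gives -22%. Compound 2 `Nc1scc(CN2CCN(c3ccc([N+](=O)[O-])cc3)CC2)c1C(=O)c1ccc(Cl)cc1` bears a 4-nitrophenyl, and in this assay compound 2 gives -13%. Compound 3 `Nc1scc(CN2CCN(c3cccc4ccccc34)CC2)c1C(=O)c1ccc(Cl)cc1` bears a naphthalen-1-yl, and in this assay compound 3 gives 0%, the highest of the three numbers and so the weakest effect seen here: the step of a number 22 percentage points higher from compound 1 to compound 3 (beyond the scatter) and the step of a number 13 percentage points higher from compound 2 to compound 3 (beyond the scatter) both lie beyond the scatter, while a number 9 percentage points higher from compound 1 to compound 2 (within the scatter) does not. Compound 4 `Nc1scc(CN2CCN(c3ccc(F)c(F)c3)CC2)c1C(=O)c1ccc(Cl)cc1` carries the change (3,4-difluorophenyl in place of naphthalen-1-yl on an amine nitrogen in a ring). The two steps that bear on it are the ones in which naphthalen-1-yl took the place of 3,5-dichlorophenyl or of 4-nitrophenyl and the number rose; running the other way, from naphthalen-1-yl back to a single substituted ring, a fall is expected. Compound 4 is therefore expected to show a number 15 percentage points lower from compound 3 to compound 4 (beyond the scatter), landing near -15%, within a range from -30% to 0%.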

Compound 4, a percentage reported as activity, at one concentration (the size of the read-out at that concentration, not a potency): -34%
For compound 4 the middle estimate is 19 percentage points above the measured one; the whole stated range lies above it.
By their numbers in this assay, from the lowest: compound 4; then compounds 1 and 2 (each within the scatter of the next); then compound 3.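

Swapping the two-ring naphthalen-1-yl for the single-ring 3,4-difluorophenyl on the ring nitrogen gives a number 34 percentage points lower from compound 3 to compound 4 (beyond the scatter) in this assay, the largest step seen at this position. Single substituted rings also separate from one another here, something compounds 1 and 2 could not show, being within the scatter of each other: there is a number 21 percentage points lower from compound 2 to compound 4 (beyond the scatter) and also a number 12 percentage points lower from compound 1 to compound 4 (beyond the scatter), which leaves compound 4 with the lowest number of the four. No measurement in hand explains this order.

Going by these compounds, it remains open whether the effect needs both fluorine atoms, since a plain phenyl ring and a phenyl ring with a single fluorine are absent from this set. On these data alone, how a phenyl ring bearing a methoxy group would compare is also open.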